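Swapping 4-methylcyclohexyl for 4-nitrophenyl in a small amide series

The source may hold more compounds than are shown below. What is called first, only, known or untested is meant among the compounds shown, and "the series" means these compounds.

Compound 1 `CCCCNC(=O)N1Cc2c(NC(=O)c3ccccc3)nn(C(=O)C3CC3)c2C1` gives 3470 nM
Compound 2 `O=C(Nc1nn(C(=O)C2CC2)c2c1CN(C(=O)c1ccccc1)C2)c1ccccc1` gives 1240 nM
Compound 3 `CC(=O)n1nc(NC(=O)c2ccccc2)c2c1CN(C(=O)C1CCC(C)CC1)C2` gives 12200 nM

Of the compounds shown here, three have been measured in a functional assay on HCT-116 cells (Homo sapiens) for cytotoxicity, read by sulforhodamine B assay, with a stated time of 48 h (on this read-out lower numbers stand for stronger inhibition and higher numbers for weaker inhibition), so far. Compound 3 holds the highest of the three numbers, with compound 1 nearer to it and compound 2 furthest away.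

The next compound is compound 4 `CC(=O)n1nc(NC(=O)c2ccccc2)c2c1CN(C(=O)c1ccc([N+](=O)[O-])cc1)C2` which is not yet measured. It carries 4-nitrophenyl in place of 4-methylcyclohexyl on a carbonyl carbon, whose other neighbour is an amide-type nitrogen in a ring. The counted difference is 4-nitrophenyl in place of 4-methylcyclohexyl on a carbonyl carbon and nothing else changes.

Within the data shown here, one measured step bears on this change, namely a 2.8-fold lower number from compound 1 to compound 2 (0.45 log units; beyond the scatter) with phenyl in place of butylamino on a carbonyl carbon. That step is modest but beyond the scatter. Among the measured compounds shown here, it starts from a different group, so it offers only a loose guide, and no measured compound carries 4-nitrophenyl. Compound 2 has phenyl on that carbonyl carbon and gives 1240 nM in this assay but it differs from compound 3 in more than one place.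

A modest move towards a lower number therefore seems likely. The expected step is a 3.5-fold lower number from compound 3 to compound 4 (0.54 log units; beyond the scatter) as an estimate only. Compound 4 is estimated at 3500 nM with an expected range from 1000 nM to 12000 nM on this slender evidence.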

Compound 4, half-maximal inhibitory concentration: 16200 nM
Beside the measured number, compound 4's estimate is 4.6-fold (0.67 log units) below it; measured number outside the range, above it.
By their numbers in this assay, from the lowest: compound 2; then compound 1; then compounds 3 and 4 (each within the scatter of the next).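

In this assay, placing 4-nitrophenyl where 4-methylcyclohexyl stood, on a carbonyl carbon whose other neighbour is an amide-type nitrogen in a ring, gives a 1.3-fold higher number from compound 3 to compound 4 (0.12 log units; within the scatter), so this pair of groups cannot be told apart at this position on the core of compound 3. Among these compounds, the only earlier step at such a carbonyl carbon, a 2.8-fold lower number from compound 1 to compound 2 (0.45 log units; beyond the scatter), involved a different pair of groups on a different background, and the new step shows that its size does not carry over to this exchange of one six-membered ring for another. No measured information is available to account for the result.

What the compounds leave open is whether a 4-aminophenyl or 4-carboxyphenyl group on this carbonyl carbon would move the number beyond the scatter, and whether plain phenyl there would stay level with the two groups compared here. From the compounds shown here alone, it also remains open whether the same exchange would read alike on the core of compound 2, which carries cyclopropylcarbonyl in place of acetyl.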